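Methylating the Amine of Compound 2: What to Expect

A few compounds are considered here, and "the series" means these few. Any claim that something is new, unique, unknown or untested is made for them only; others in the source may bear on it.

Compound 1, `c1ccc2c(c1)CCC2NC1CCN(CCCc2c[nH]c3ccc(-n4cnnc4)cc23)CC1`, gives 8.9 nM in an assay on CHO cells for displacement of a labelled ligand from 5-hydroxytryptamine receptor 1D (Homo sapiens); on this read-out lower numbers stand for stronger inhibition and higher numbers for weaker inhibition.
Compound 2, `CC(=O)Nc1ccc(CNC2CCN(CCCc3c[nH]c4ccc(-n5cnnc5)cc34)CC2)cc1`, gives 3 nM in this assay.

Compound 2 stands lowest of the two measured numbers; its nearest neighbour is compound 1, and the step of a 3.0-fold lower number from compound 1 to compound 2 (0.47 log units; beyond the scatter) separates them. Compound 3, `CC(=O)Nc1ccc(CN(C)C2CCN(CCCc3c[nH]c4ccc(-n5cnnc5)cc34)CC2)cc1`, has not been measured yet. It differs from compound 2 by methyl in place of hydrogen on an amine nitrogen. Among the measured compounds shown here, the one measured step, a 3.0-fold lower number from compound 1 to compound 2 (0.47 log units; beyond the scatter), exchanges the larger group that hangs on that same amine nitrogen, not a hydrogen for a methyl, so no measured step speaks directly to this change. With nothing else to go on, the expectation for compound 3 in this assay is a number close to that of compound 2, and the step of a 1.3-fold higher number from compound 2 to compound 3 (0.12 log units; within the scatter) is expected to stay within the scatter. The estimate for compound 3 is therefore 4 nM, in a range from 1.5 nM to 12 nM.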

Compound 3, half-maximal inhibitory concentration: 19 nM
For compound 3 the middle estimate is 4.8-fold (0.68 log units) below the measured one; measured number above the stated range.
By their numbers in this assay, from the lowest: compound 2; then compound 1; then compound 3.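

Up to this point, only the larger group on this amine nitrogen had been exchanged, while its hydrogen stayed in place. Replacing that hydrogen with methyl gives, in this assay, a 6.3-fold higher number from compound 2 to compound 3 (0.80 log units; beyond the scatter), so one added carbon on this nitrogen moves the number beyond the scatter. That shift is larger than the one seen on exchanging the whole larger group, a 3.0-fold lower number from compound 1 to compound 2 (0.47 log units; beyond the scatter), and it runs in the opposite direction, toward weaker inhibition. Nothing available here explains why the methyl has this effect.

As far as these compounds go, it remains open whether an ethyl or an acetyl group on the same nitrogen would raise the number further. From the compounds shown here alone, it is also open whether methyl would do the same with the 2,3-dihydro-1H-inden-1-yl group of compound 1 on that nitrogen.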